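Oxazole ketone series: truncating the aryl substituent

The source may hold more compounds than are shown below. What is called first, only, known or untested is meant among the compounds shown, and "the series" means these compounds.

Measured so far:
compound 1 `COC(=O)c1cc(-c2cnc(C(=O)CCc3ccc(-c4ccccc4)cc3)o2)ccn1`: 1.5 nM
compound 2 `COC(=O)c1cccc(-c2cnc(C(=O)CCc3ccc(OC4CCN(C(=O)OC(C)(C)C)CC4)cc3)o2)n1`: 32 nM
compound 3 `O=C(O)c1cccc(-c2cnc(C(=O)CCc3ccc(-c4ccc(CN5CCCCC5)cc4)cc3)o2)n1`: 44 nM

All three compounds share the acyl-oxazole core and were tested in an assay for inhibition of Fatty-acid amide hydrolase 1 (Rattus norvegicus); a lower number here means a stronger inhibitor, a higher number a weaker inhibitor. Compound 1 gives 1.5 nM and has the lowest number of the three; compound 2 and compound 3 both sit well beyond the scatter from it, with compound 2 the nearer of the two. Among the compounds with values here, compound 2 and compound 3 differ from compound 1 in more than one place, so no single step between measured compounds can be read off.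

Compound 4 `COC(=O)c1cnc(C(=O)CCc2ccc(-c3ccccc3)cc2)o1` keeps the biphenyl tail and the ketone linker of compound 1 and changes only the substituent on the five-membered ring: methoxycarbonyl in place of 2-(methoxycarbonyl)pyridin-4-yl on an aromatic carbon. Since the only measured variation involves that substituent together with the tail, the step is not directly anchored, but the loss of the pyridyl ring is a large reduction in what sits on the core. The expected step is a clear loss of potency, a 13-fold higher number from compound 1 to compound 4 (1.12 log units; beyond the scatter), beyond the scatter. Compound 4 is therefore estimated at 20 nM, within the range 4 nM to 100 nM.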

Compound 4, inhibition constant: 1.5 nM
Compound 4: the middle estimate sits 13-fold (1.12 log units) above what was measured; measured number outside the range, below it.
By their numbers in this assay, from the lowest: compounds 1 and 4 (each within the scatter of the next); then compounds 2 and 3 (each within the scatter of the next).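

At the aromatic carbon next to the ring oxygen of the five-membered ring, this assay shows no change at the digits printed from compound 1 to compound 4 (within the scatter) when methoxycarbonyl replaces 2-(methoxycarbonyl)pyridin-4-yl. With the biphenyl tail and ketone linker held, the substituent can therefore lose its six-membered aromatic ring and shrink from 10 heavy atoms to 4 without a change beyond the scatter, a reading that compounds 2 and 3, which differ from compound 1 in more than one place, could not give. No measurement at hand accounts for the two substituents reading alike.

As far as these compounds go, it remains open whether a carboxylic acid or a primary amide on the same carbon, with the tail of compound 4 held, would keep the number in this assay at this level. Also open, from the compounds shown here alone, is whether the same replacement would read alike with the tail of compound 2 or compound 3.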